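A few compounds are considered here, and "the series" means these few. Any claim that something is new, unique, unknown or untested is made for them only; others in the source may bear on it.

Three related compounds have been measured in a functional assay on A549 cells (Homo sapiens) for antiproliferative activity, read by MTT assay, with a stated time of 72 h; on this read-out higher numbers stand for weaker inhibition and lower numbers for stronger inhibition. In this assay, compound 1 `O=S1(=O)C=Cc2ccc(Nc3ccc(C(F)(F)F)cc3)cc21` gives 1140 nM, compound 2 `O=S1(=O)C=Cc2cccc(Nc3ccc(OC(F)(F)F)cc3)c21` gives 1570 nM, and compound 3 `COc1cc(Nc2cccc3c2S(=O)(=O)C=C3)cc(OC)c1OC` gives 950 nM. Compound 2 stands within the usual scatter of both other compounds, so these numbers set no order among the three.

Compound 4 `O=S1(=O)C=Cc2cccc(Nc3ccc(Cl)cc3)c21` has not yet been measured. It is compound 2 with one change: chloro in place of trifluoromethoxy on an aromatic carbon, para to a large group (chloro in place of trifluoromethoxy on an aromatic carbon). For the measured compounds named here, no measured pair here differs in just one place, so this swap has no direct precedent. Going by the values given here, the only guide is that compound 1 at 1140 nM and compound 3 at 950 nM differ in structure from compound 2 yet remain within the scatter of its 1570 nM. The estimated change, a 1.2-fold lower number from compound 2 to compound 4 (0.08 log units; within the scatter), is therefore expected to stay within the scatter, with no firm direction. For compound 4 the expected value is 1300 nM, with an estimated range from 550 nM to 3000 nM.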

Compound 4, half-maximal inhibitory concentration: 1040 nM
Beside the measured number, compound 4's estimate is 1.3-fold (0.10 log units) above it, within the range that was stated.
By their numbers in this assay, from the lowest: compounds 3, 4, 1 and 2 (each within the scatter of the next).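

In this assay, for the compounds shown here, chloro in place of trifluoromethoxy on this aromatic carbon, para to a large group, gives a 1.5-fold lower number from compound 2 to compound 4 (0.18 log units; within the scatter) in the first comparison here between two compounds that differ in one place. At this position, then, a group of 5 heavy atoms with 1 hydrogen-bond acceptor can give way to chloro, with 1 heavy atom and no acceptor, without a change that this assay can separate from the scatter. No measurement shown here speaks to what lies behind this small step.

The compounds shown leave open whether an amine or a carboxylic acid on this carbon would move the number beyond the scatter. They also leave open whether the same swap would give a similarly small step on the core of compound 1.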